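Two Writhing-Test Compounds and an Untested Methoxy Analogue

This account rests on a few compounds, and the source may have more. Where it says the series, first, only, none or still open, it means among the compounds named here.

Compound 1: `CC1C(=O)CC(c2ccc(Cl)cc2)N(C(=O)CN2CCN(C)CC2)C1c1ccc(N(C)C)cc1` — 28.1% in a functional assay on the whole organism for inhibition, with Mus musculus as the target, in the writhing test, with a stated time of 1 h, at a dose of 60 mg/kg by the oral route; on this read-out higher numbers stand for more inhibition at the one dose given (going by the name of the read-out) and lower numbers for less inhibition
Compound 2: `CC1C(=O)CC(c2ccc(Cl)cc2)N(C(=O)CCl)C1c1ccc(O)cc1` — 39.7%

Compound 1 gives the lower of the two numbers in this assay; compound 2 stands higher by a gap beyond the usual scatter, though the two differ in more than one place, so only their values can be set side by side. Compound 3, `COc1ccc(C2C(C)C(=O)CC(c3ccc(Cl)cc3)N2C(=O)CN2CCN(C)CC2)cc1`, is not yet measured. Against compound 1 it shows a single change: methoxy in place of dimethylamino on an aromatic carbon. Among the compounds with values here, no measured pair isolates this change, so the step in this assay is expected to be small, in either direction and hardly beyond the scatter. Compound 3 is expected to give 32%, within a range from 15% to 50%. The step of a number 3.9 percentage points higher from compound 1 to compound 3 (within the scatter) is thus expected to be modest.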

Compound 3, a percentage reported as inhibition, in the whole organism at one dose (the size of the read-out at that dose, not a potency) in the Mus musculus assay: 53.1%
Compound 3: middle estimate off by 21.1 percentage points, on the low side; measured number outside the range, above it.
By their numbers in the Mus musculus assay, from the lowest: compound 1; then compound 2; then compound 3.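

Within the data shown here, in the Mus musculus assay, methoxy in place of dimethylamino on an aromatic carbon, para to a large group, gives a number 25 percentage points higher from compound 1 to compound 3 (beyond the scatter) and so provides the first reading of this change, which no earlier pair isolated. In a physicochemical assay for lipophilicity, using the shake flask method (a higher number here means a more lipophilic compound, a lower number a more polar compound), compound 1 gives 1.35 and compound 3 gives 1.48, which is a number 0.13 log units higher from compound 1 to compound 3 (within the scatter) and does not separate the two. Nothing at hand accounts for the step in inhibition. The compounds shown leave open whether ethoxy, fluorine or a primary amine at this place would match methoxy. They also leave open whether the step would carry over to a different amide side chain.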